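Working notes: compound 2 to compound 3

A few compounds are considered here, and "the series" means these few. Any claim that something is new, unique, unknown or untested is made for them only; others in the source may bear on it.

Measured so far in a functional assay on HT-29 cells (Homo sapiens) for antiproliferative activity, read by sulforhodamine B assay, with a stated time of 72 h; on this read-out lower numbers stand for stronger inhibition and higher numbers for weaker inhibition:
- compound 1 `O=C(Cn1nc(-c2ccccc2)c2ccccc2c1=O)Nc1ccccc1Cl`: 88600 nM
- compound 2 `O=C(Cn1nc(Cc2ccccc2)c2ccccc2c1=O)Nc1ccc(F)cc1`: 98000 nM

Compound 2, at 98000 nM, and compound 1, at 88600 nM, lie within the usual scatter of each other, so neither can be ranked against the other on these numbers.

Among the compounds with values here, compound 3 `O=C(Cn1nc(Cc2ccccc2)c2ccccc2c1=O)Nc1ccccc1Cl` has no measurement yet. It differs from compound 2 by 2-chlorophenyl in place of 4-fluorophenyl on an amide-type nitrogen.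

Within the data shown here, no measured pair isolates this change, so the expectation rests only on the two values in hand. In this assay no step beyond the scatter is expected, and the estimated 1.2-fold lower number from compound 2 to compound 3 (0.09 log units; within the scatter) stays within it. For compound 3 the expected value is 80000 nM, with an estimated range of 35000 nM to 170000 nM.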

Compound 3, half-maximal inhibitory concentration: 42800 nM
The estimate for compound 3 lay 1.9-fold (0.27 log units) above the measured number, and the stated range covers the measured number.
By their numbers in this assay, from the lowest: compound 3; then compounds 1 and 2 (each within the scatter of the next).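

In this assay the group on the amide-type nitrogen now has a readable effect: 2-chlorophenyl in place of 4-fluorophenyl gives a 2.3-fold lower number from compound 2 to compound 3 (0.36 log units; beyond the scatter) with benzyl held on the aromatic carbon. The aromatic carbon also becomes readable, since benzyl in place of phenyl gives a 2.1-fold lower number from compound 1 to compound 3 (0.32 log units; beyond the scatter) with 2-chlorophenyl held on the amide-type nitrogen. Both steps are modest, and nothing in hand accounts for either one.

The step at the amide-type nitrogen changes the halogen and where it sits together, so the compounds shown do not tell which of the two carries it. Also open, from the compounds shown here alone, is whether a longer chain in place of benzyl, or an amine in place of the halogen, would move the number further in either direction.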